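This account rests on a few compounds, and the source may have more. Where it says the series, first, only, none or still open, it means among the compounds named here.

Compound 2, `COc1cc(-c2cc(/C=C/C(=O)c3ccc(N)cc3)[nH]n2)cc(OC)c1OC`, carries on its shared core a trimethoxyphenyl group and a 4-aminophenyl ketone; compound 1, `COc1ccc(-c2cc(/C=C/C(=O)c3ccc(N)cc3)[nH]n2)cc1`, differs from it in carrying a single methoxy group on that phenyl ring. In a functional assay on HCC 2998 cells (Homo sapiens) for inhibition, read by sulforhodamine B assay, with a stated time of 48 h (a higher number here means a weaker inhibitor of growth, a lower number a stronger inhibitor of growth), compound 2 gives 3630 nM. Compound 1 gives 3360 nM in this assay. These two numbers sit within the usual scatter of each other, so on the evidence shown compound 2 cannot be told apart from compound 1, and it is the only neighbour against which compound 2 can be placed.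

Compound 3, `COc1cc(-c2cc(/C=C/C(=O)c3ccc(Cl)c(Cl)c3)[nH]n2)cc(OC)c1OC`, has not yet been measured. It differs from compound 2 in one place: 3,4-dichlorophenyl in place of 4-aminophenyl on a carbonyl carbon. Among the measured compounds shown here, no measured pair shows what this kind of exchange does in this assay, so the expectation for compound 3 rests on compound 2 alone and is held loosely. The step from compound 2 to compound 3 is expected to be a 1.3-fold lower number from compound 2 to compound 3 (0.11 log units; within the scatter), that is, no more than a shift within or just beyond the scatter, with the direction uncertain. Compound 3 is therefore estimated at 2800 nM, with a range from 700 nM to 11000 nM.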

Compound 3, concentration for total growth inhibition: 31400 nM
Compound 3: middle estimate off by 11-fold (1.05 log units), on the low side; the whole stated range lies below it.
By their numbers in this assay, from the lowest: compounds 1 and 2 (each within the scatter of the next); then compound 3.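

The earlier pair changed only the methoxy substitution on the phenyl ring and left the number in this assay within the scatter, so it said nothing about the aryl group on the carbonyl carbon. Among the compounds shown here, this exchange shows that this position is not silent: 3,4-dichlorophenyl in place of 4-aminophenyl gives an 8.7-fold higher number from compound 2 to compound 3 (0.94 log units; beyond the scatter), so here the 4-aminophenyl ketone is the stronger inhibitor of growth, and this is the first step seen to lie beyond the scatter. Nothing among the data shown explains why the exchange has an effect of this size.

The exchange removes the amine and brings in the two chlorine atoms in a single step, so the compounds shown leave open whether the loss of the one or the arrival of the other sets the size of the step, a question that a plain phenyl, a chlorophenyl or a hydroxyphenyl on the same carbonyl carbon could begin to separate. They also leave open whether the same exchange would give a step of similar size on the single-methoxy ring of compound 1, since it is seen here only with the trimethoxyphenyl group.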